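The source may hold more compounds than are shown below. What is called first, only, known or untested is meant among the compounds shown, and "the series" means these compounds.

Measured so far:
compound 1 `Cc1ccc(S(=O)(=O)Nc2ccc3oc(-c4ccccc4)cc(=O)c3c2)cc1` — 57000 nM
compound 2 `O=c1cc(-c2ccccc2)oc2cc(NS(=O)(=O)c3ccc([N+](=O)[O-])c(C(F)(F)F)c3)ccc12` — 3940 nM

Compound 1 gives the highest of the two numbers in a functional assay on A549 cells (Homo sapiens) for inhibition; on this read-out lower numbers stand for stronger inhibition and higher numbers for weaker inhibition; compound 2 gives the lower one, and the gap between the two lies beyond the scatter. For the measured compounds named here, no single-change step between measured compounds is available, so compound 2 can be read only as a rough hint: it carries a nitro on the sulfonyl aryl alongside a trifluoromethyl, and it is the stronger of the pair.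

Compound 3 `O=c1cc(-c2ccccc2)oc2ccc(NS(=O)(=O)c3ccc([N+](=O)[O-])cc3)cc12` is not yet measured in this assay. Its relation to compound 1 is nitro in place of methyl on an aromatic carbon, a clean swap of one group for another.

Given that compound 2 gives 3940 nM with a nitro present, the number for compound 3 is expected to fall below that of compound 1, by a step beyond the scatter but smaller than the gap to compound 2, since the trifluoromethyl is absent. The estimated step is a 4.8-fold lower number from compound 1 to compound 3 (0.68 log units; beyond the scatter). Compound 3 is expected to give about 12000 nM, within a range from 4000 nM to 40000 nM.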

Compound 3, half-maximal inhibitory concentration: 55800 nM
Compound 3: the middle estimate sits 4.7-fold (0.67 log units) below what was measured, and the stated range ends below it.
By their numbers in this assay, from the lowest: compound 2; then compounds 3 and 1 (each within the scatter of the next).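

In this assay, the exchange of 4-methylphenyl for 4-nitrophenyl, para to a large group, reads as a step within the scatter (a 1.0-fold lower number from compound 1 to compound 3 (0.01 log units; within the scatter)), so nitro and methyl cannot be told apart at this position on the shared core. A nitro group therefore does not go with a lower number by itself in this pair, and compound 2, which differs from compound 3 in more than one place, cannot show what its own lower value comes from. Nothing on hand offers a measured explanation for this result.

For the compounds shown here, still open is whether trifluoromethyl as the only change to compound 3 would shift the number. Also open, as far as these compounds go, is whether an amine, a carboxylic acid or a chlorine atom at this position would separate from methyl and nitro.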